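Replacing Cyclopentyl with a Hydroxypropyl Chain on the Amide

The compounds below may be only part of what the source reports. "The series", "measured", "known", "first", "only" and "open" are said of these compounds alone.

Measured so far:
compound 1 `N=c1oc2ccc(Br)cc2cc1C(=O)NC1CCCCC1` gives 10%
compound 2 `N=c1oc2ccc(Br)cc2cc1C(=O)NCCO` gives 15%
compound 3 `N=c1oc2ccc(Br)cc2cc1C(=O)NC1CCCC1` gives 28%

These three compounds share one core and differ only in the group on the amide-type nitrogen; all were tested in an assay on HEK293 cells for displacement of a labelled ligand from adenosine receptor A2b (Homo sapiens), read by scintillation counting, with a stated time of 30 min, tested at 10 uM; a lower number here means less inhibition, a higher number more inhibition at the concentration tested (going by the name of the read-out). Compound 3 stands highest of the three: the step of a number 18 percentage points higher from compound 1 to compound 3 (beyond the scatter) and the step of a number 13 percentage points higher from compound 2 to compound 3 (beyond the scatter) both point upward, while the step of a number 5 percentage points higher from compound 1 to compound 2 (within the scatter) stays within the scatter. Compound 4 `N=c1oc2ccc(Br)cc2cc1C(=O)NCCCO` has not yet been measured; it differs from compound 3 in one place: 3-hydroxypropyl in place of cyclopentyl on an amide-type nitrogen. The measured step that bears most directly on this change is a number 13 percentage points higher from compound 2 to compound 3 (beyond the scatter), which runs in the opposite direction: a 2-hydroxyethyl chain replaced by a cyclopentyl ring gave a modest rise. Going back from the ring to a hydroxyalkyl chain one carbon longer is expected to undo most of that rise, giving a modest drop in this assay. The expected change is a number 13 percentage points lower from compound 3 to compound 4 (beyond the scatter). For the measured compounds named here, no measured pair compares 2-hydroxyethyl with 3-hydroxypropyl, so the extra carbon adds uncertainty. For compound 4 the expected value in this assay is 15%, with a range from 4% to 28%.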

Compound 4, a percentage reported as inhibition, at one concentration (the size of the read-out at that concentration, not a potency): 25%
Estimate against measurement, compound 4: 10 percentage points below, and the stated range covers the measured number.
By their numbers in this assay, from the lowest: compounds 1, 2, 4 and 3 (each within the scatter of the next, the first and the last beyond it).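

Swapping the cyclopentyl ring for the open 3-hydroxypropyl chain leaves the number in this assay within the scatter (a number 3 percentage points lower from compound 3 to compound 4 (within the scatter)), so at this amide-type nitrogen a ring of carbon only is not required for a reading at this level, even though the entering chain brings a hydrogen-bond donor and a hydrogen-bond acceptor that cyclopentyl lacks. The added carbon gives a step from the shorter hydroxy chain that also stays within the scatter (a number 10 percentage points higher from compound 2 to compound 4 (within the scatter)), but the 3-hydroxypropyl chain does separate from cyclohexyl (a number 15 percentage points higher from compound 1 to compound 4 (beyond the scatter)), something the 2-hydroxyethyl chain did not do. No measurement at hand offers an explanation for these numbers.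

The compounds shown cannot tell whether the hydroxy group contributes anything here, since a plain propyl chain without it is not among them. From the compounds shown here alone, it also stays open whether a longer chain such as 4-hydroxybutyl, or a chain ending in an amine or a carboxylic acid instead of the hydroxy, would move the number beyond the scatter from the compounds seen so far.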